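The source may report more compounds than this note shows. Statements on the series, on what has been measured and on what is new or still open speak of the compounds shown alone.

Measured so far in a functional assay on U-87MG ATCC cells for antiproliferative activity against U-87 MG (Homo sapiens), read by MTT assay, with a stated time of 48 h, tested at 10 uM; a higher number here means a weaker effect of the compound at the concentration tested, a lower number a stronger effect:
compound 1 `Cc1nc(-c2ccc(Cl)cc2)sc1C(=O)CSc1nc(-c2ccccc2)c(C#N)c(=O)[nH]1` gives 83.1%
compound 2 `COc1ccc(-c2nc(SCC(=O)c3sc(-c4ccccc4)nc3C)[nH]c(=O)c2C#N)cc1` gives 90.4%
compound 3 `Cc1nc(-c2ccccc2)sc1C(=O)CSc1nc(-c2cccc(Cl)c2)c(C#N)c(=O)[nH]1` gives 83.7%

Compound 3 sits between the other two, and all three numbers lie within the usual scatter of one another, so no ordering among them can be read from this assay. Compound 4 `Cc1nc(-c2ccccc2)sc1C(=O)CSc1nc(-c2ccccc2)c(C#N)c(=O)[nH]1` differs from compound 3 in a single place: hydrogen in place of chloro on an aromatic carbon. Among the measured compounds shown here, the one step so far that touched this same ring, a number 6.7 percentage points lower from compound 2 to compound 3 (within the scatter), stayed within the scatter, and that is the only guide available. The step from compound 3 to compound 4 is therefore expected to be small, a number 1.3 percentage points higher from compound 3 to compound 4 (within the scatter), with no direction beyond the scatter. Compound 4 is estimated at 85%, in a range from 72% to 96%.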

Compound 4, a percentage reported as activity, at one concentration (the size of the read-out at that concentration, not a potency): 87.5%
Compound 4: middle estimate off by 2.5 percentage points, on the low side, and the stated range covers the measured number.
By their numbers in this assay, from the lowest: compounds 1, 3, 4 and 2 (each within the scatter of the next).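

With hydrogen in place of the substituent on this ring, compound 4 gives a reference point in this assay: removing either chloro or methoxy leaves the number within the scatter, with a number 3.8 percentage points higher from compound 3 to compound 4 (within the scatter) and a number 2.9 percentage points lower from compound 2 to compound 4 (within the scatter) as the two readings. Removing a chloro from a different place in the molecule also stays within the scatter, with a number 4.4 percentage points higher from compound 1 to compound 4 (within the scatter) as its reading. Nothing measured here bears on these steps.

On these data alone, whether an amine, a carboxylic acid or a longer chain on this ring would give a step beyond the scatter remains open.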